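Swapping the amide nitrogen substituent on a biaryl ether

This account rests on a few compounds, and the source may have more. Where it says the series, first, only, none or still open, it means among the compounds named here.

Compound 3 `CCOc1ccc(-c2cccc(C(=O)N3CCCC3)c2)cc1` is measured in an assay on COS-7 cells for inhibition of patatin-like phospholipase domain-containing protein 2 (Mus musculus) (a higher number here means a weaker inhibitor, a lower number a stronger inhibitor), where compound 3 gives 160000 nM. Compound 1 `CCOc1ccc(-c2cccc(S(=O)(=O)NC)c2)cc1`, which carries a methylsulfamoyl group at the same place, gives 200000 nM in this assay, and the step of a 1.3-fold lower number from compound 1 to compound 3 (0.10 log units; within the scatter) stays within the scatter. Compound 2 `CCOc1ccc(-c2ccccc2)cc1`, with hydrogen at that position, reaches only the limit of the assay, > 200000 nM; the step of an at least 1.2-fold lower number from compound 2 to compound 3 (0.09 log units; that floor lies within the scatter) is therefore read against a limit, as is the limit of > 200000 nM in this assay, at which 1 of the 3 values shown sits. Compound 3 thus sits alongside compound 1, with no separation beyond the scatter.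

Compound 4 `CCOc1ccc(-c2cccc(C(=O)NC)c2)cc1` differs from compound 3 by one change: methylamino in place of pyrrolidin-1-yl on a carbonyl carbon. Going by the values given here, no measured step swaps one amide substituent for another; the steps seen so far exchange whole groups on the aromatic carbon and remain within the scatter or at the limit. On that basis the step from compound 3 to compound 4 is expected to be a 1.1-fold higher number from compound 3 to compound 4 (0.05 log units; within the scatter), that is, no change beyond the scatter. Compound 4 is therefore estimated at 180000 nM, with a range from 90000 nM to 350000 nM.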

Compound 4, half-maximal inhibitory concentration: > 200000 nM
Compound 4: no number, only a limit (the forecaster's own chance of this, stated with the estimate: 40%); middle value at least 1.1-fold (0.04 log units) from the limit.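

Methylamino in place of pyrrolidin-1-yl is the first change shown within the amide group itself, and in this assay compound 4 gives > 200000 nM, which is a limit and not a number. The step reads an at least 1.2-fold higher number from compound 3 to compound 4 (0.09 log units; that floor lies within the scatter), so this change brings no lower number, but how much higher the true value lies cannot be told. Against the methylsulfamoyl group, methylcarbamoyl gives a number no lower from compound 1 to compound 4 (the limit leaves the size open), while the step from compound 2 to compound 4 cannot be read. Limits now make up a large share of this small set: the limit of > 200000 nM in this assay, at which 2 of the 4 values shown sit.

Going by these compounds, whether the ring or the amide hydrogen matters here stays open, since this change alters both at once. Dimethylamino, which has no ring and no amide hydrogen, or piperidin-1-yl, a larger ring, on the same carbonyl carbon could begin to separate the two.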